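From 4-bromobutyl to allyl on the shared core

The source may report more compounds than this note shows. Statements on the series, on what has been measured and on what is new or still open speak of the compounds shown alone.

In a functional assay on HL-60 cells (Homo sapiens) for cytotoxicity, read by MTT assay, with a stated time of 24 h (a higher number here means a weaker inhibitor, a lower number a stronger inhibitor), compound 2 `BrCCCCOc1c(Br)cc(Br)cc1Oc1ccc(Br)cc1Br` gives 25.9 ug/mL. Compound 3 `COc1ccccc1N1CCN(CCCCCOc2c(Br)cc(Br)cc2Oc2ccc(Br)cc2Br)CC1` gives 32.2 ug/mL, and compound 1 `CC(C)(C)OC(=O)N1CCCN(CCCCCOc2c(Br)cc(Br)cc2Oc2ccc(Br)cc2Br)CC1` gives 44.8 ug/mL. Compound 2 stands within the scatter of both.

Compound 4 `C=CCOc1c(Br)cc(Br)cc1Oc1ccc(Br)cc1Br` differs from compound 2 by vinyl in place of 3-bromopropyl on a saturated chain carbon bound to an oxygen on an aromatic ring; the same difference reads 4-bromobutoxy to allyloxy. For the measured compounds named here, no pair of measured compounds differs in one place, so the size of this change has not been measured directly. Compound 1 at 44.8 ug/mL and compound 2 at 25.9 ug/mL lie within the scatter despite their different chains, so no step beyond the scatter is expected in this assay. The estimate means a 1.2-fold higher number from compound 2 to compound 4 (0.06 log units; within the scatter), expected to stay within the scatter. The expected value for compound 4 is 30 ug/mL, with an estimated range of 14 ug/mL to 60 ug/mL.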

Compound 4, half-maximal inhibitory concentration: 27.9 ug/mL
Compound 4: the middle estimate sits 1.1-fold (0.03 log units) above what was measured; the measured number falls inside the stated range.
By their numbers in this assay, from the lowest: compounds 2, 4, 3 and 1 (each within the scatter of the next).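

For the compounds shown here, replacing 3-bromopropyl with vinyl on a saturated chain carbon bound to an oxygen on an aromatic ring gives, in this assay, a 1.1-fold higher number from compound 2 to compound 4 (0.03 log units; within the scatter) and is the first one-place step measured. At this position, the group can go from 4 heavy atoms with a bromine to 2 carbons with a double bond while compounds 2 and 4 stay within the scatter of each other. No supporting data explain this result.

Still open, as far as these compounds go, is whether a carboxylic acid or a primary amine at this chain end would also stay within the scatter. From the compounds shown here alone, a longer unbranched alkyl chain without bromine is equally open.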